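The source may report more compounds than this note shows. Statements on the series, on what has been measured and on what is new or still open speak of the compounds shown alone.

Two compounds of this series have numbers in a functional assay on CAKI-1 cells (Homo sapiens) for cytotoxicity, read by sulforhodamine B assay, with a stated time of 48 h; on this read-out lower numbers stand for stronger inhibition of growth and higher numbers for weaker inhibition of growth. Compound 1 `ClCc1cccc(Cn2cnc3c(Cl)ncnc32)c1` gives 2950 nM. Compound 2 `ClCc1ccc(Cn2cnc3nc(Cl)nc(Cl)c32)cc1` gives 2750 nM, the lowest of the two numbers; its nearest neighbour is compound 1, and the two lie within the scatter, so no order between them is claimed. Compound 3 `ClCc1ccc(Cn2cnc3ncnc(Cl)c32)cc1` is not yet measured. It differs from compound 2 by hydrogen in place of chloro on an aromatic carbon. For the measured compounds named here, no measured pair covers this change; a small step toward weaker growth inhibition, or none beyond the scatter, is expected. For compound 3 the estimate is 4000 nM, with a range from 1500 nM to 12000 nM. The expected step is a 1.5-fold higher number from compound 2 to compound 3 (0.16 log units; within the scatter).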

Compound 3, concentration for total growth inhibition: 4460 nM
For compound 3 the middle estimate is 1.1-fold (0.05 log units) below the measured one, within the range that was stated.
By their numbers in this assay, from the lowest: compounds 2, 1 and 3 (each within the scatter of the next).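

In this assay, for the compounds shown here, hydrogen in place of the chloro group between two ring nitrogen atoms gives a 1.6-fold higher number from compound 2 to compound 3 (0.21 log units; within the scatter) and is the only step read so far at this position. This chloro group can therefore leave without a change beyond the scatter, while the other chloro group stays in both compounds. No measurement at hand offers an explanation for this result. On these data alone, whether an amine or a methoxy group at this position would move the number beyond the scatter stays open. So does the role of the remaining chloro group.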